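Replacing a Methylphenyl with a Methylindolyl on the Core

The source may report more compounds than this note shows. Statements on the series, on what has been measured and on what is new or still open speak of the compounds shown alone.

Compound 1 `COc1ccc(-c2cc3nccc(-c4cc(OC)c(OC)c(OC)c4)n3n2)cc1N` — 283 nM
Compound 2 `COc1cc(-c2ccnc3cc(-c4ccc(C)cc4)nn23)cc(OC)c1OC` — 21 nM
Compound 3 `COc1cc(-c2cc3nccc(-c4c[nH]c5ccccc45)n3n2)cc(OC)c1OC` — > 10000 nM, a limit of the assay rather than a number

All three were tested in a functional assay on HeLa cells (Homo sapiens) for inhibition, read by CCK-8 assay, with a stated time of 48 h; a higher number here means a weaker inhibitor, a lower number a stronger inhibitor. Compound 2 gives the lower of the two actual numbers, and the change a 13-fold lower number from compound 1 to compound 2 (1.13 log units; beyond the scatter) shows that swapping the group on that position of the shared core can move the result a long way. Compound 3 sits at the limit of > 10000 nM in this assay, at which 1 of the 3 values shown sits, and so gives no number to compare.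

Compound 4 `COc1cc(-c2ccnc3cc(-c4ccc5ccn(C)c5c4)nn23)cc(OC)c1OC` has not yet been measured. It differs from compound 2 in one place: 1-methyl-1H-indol-6-yl in place of 4-methylphenyl on an aromatic carbon. Among the compounds with values here, the only measured step that touches this position is a 13-fold lower number from compound 1 to compound 2 (1.13 log units; beyond the scatter), which was large, so a step beyond the scatter on going from compound 2 to compound 4 is plausible, though its direction is not fixed by the data. Compound 3, which carries an indole of a different kind elsewhere on the core, shows only a limit and cannot guide the direction.

Compound 4 is therefore expected to give about 60 nM, within roughly 10 nM to 600 nM, meaning an estimated step of a 2.9-fold higher number from compound 2 to compound 4 (0.46 log units; beyond the scatter).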

Compound 4, half-maximal inhibitory concentration: 187 nM
Estimate against measurement, compound 4: 3.1-fold (0.49 log units) below; measured number inside the range.
By their numbers in this assay, from the lowest: compound 2; then compounds 4 and 1 (each within the scatter of the next). At a limit, above all of these: compound 3.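

The new result gives this position on the shared core a third group, and in this assay the larger, two-ring 1-methyl-1H-indol-6-yl does not keep up with 4-methylphenyl: the swap gives an 8.9-fold higher number from compound 2 to compound 4 (0.95 log units; beyond the scatter) and so shows that a change at this position can also raise the number when the group that enters is an indole. Against the other group at this position, the picture is different, as a 1.5-fold lower number from compound 1 to compound 4 (0.18 log units; within the scatter) leaves 1-methyl-1H-indol-6-yl and 3-amino-4-methoxyphenyl impossible to tell apart. Of the three groups compared here, 4-methylphenyl in compound 2 alone stands apart, and two quite different replacements for it both give clearly higher numbers.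

As far as these compounds go, what the methyl group of 4-methylphenyl contributes stays open, and a plain phenyl, a 4-chlorophenyl or a 1H-indol-6-yl without its methyl group at the same place would each help to separate the effect of that methyl from the effect of the ring. The data shown hold no measurement that accounts for the gap between compound 2 and compound 4.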